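Methoxy for Methyl on a Bromobenzamide Sulfonamide

This account rests on a few compounds, and the source may have more. Where it says the series, first, only, none or still open, it means among the compounds named here.

Of the compounds shown here, three have been measured in a functional assay on HEK293 cells for agonist activity at probable G-protein coupled receptor 27 (Homo sapiens), read by a luciferase reporter and beta-arrestin recruitment, with a stated time of 10 min; on this read-out higher numbers stand for an effect only at larger amounts of compound and lower numbers for an effect already at smaller amounts. Compound 1 `COc1ccc(NS(=O)(=O)c2ccc(NC(=O)c3ccc(Cl)cc3Cl)cc2)cc1` carries a methoxy group on its outer ring; in this assay compound 1 returns only a limit, > 100000 nM. Compound 2 `Cc1ccc(NS(=O)(=O)c2ccc(NC(=O)c3ccc(Cl)cc3Cl)cc2)cc1` carries a methyl group in the same place; in this assay compound 2 likewise returns only a limit, > 100000 nM. The change from compound 2 to compound 1 is methoxy in place of methyl on an aromatic carbon, and the step that the two limits leave unreadable from compound 2 to compound 1 cannot be read because both values sit at the limit of > 100000 nM in this assay, at which 2 of the 3 values shown sit.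

Among the compounds with values here, compound 3 `Cc1cc(Br)ccc1C(=O)Nc1ccc(S(=O)(=O)Nc2ccccc2)cc1` is the only one to give a number: in this assay compound 3 gives 851 nM. The difference between the core of compound 3 and the core of compound 2 is not broken down here.

Compound 4 `COc1cc(Br)ccc1C(=O)Nc1ccc(S(=O)(=O)Nc2ccccc2)cc1` has not yet been measured. It differs from compound 3 by the same kind of change (methoxy in place of methyl on an aromatic carbon), though the surroundings differ: in compound 4 the methoxy sits ortho to a large group and meta to a bromo group, whereas in compound 1 it sits para to a large group. The earlier step offers no readable size to lean on. The step from compound 3 to compound 4 is expected to be modest, a 1.8-fold higher number from compound 3 to compound 4 (0.25 log units; within the scatter), resting on compound 3 giving 851 nM in this assay. Compound 4 is therefore estimated at about 1500 nM, within a range from 400 nM to 8000 nM.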

Compound 4, half-maximal effective concentration: 1020 nM
For compound 4 the middle estimate is 1.5-fold (0.17 log units) above the measured one, within the range that was stated.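

In this assay, methoxy in place of methyl on this aromatic carbon gives a 1.2-fold higher number from compound 3 to compound 4 (0.08 log units; within the scatter) and so, on the core of compound 3, the 4-bromo-2-methylphenyl and 4-bromo-2-methoxyphenyl forms cannot be told apart. This is the only readable instance of the change among the compounds shown, so it shows that the change is tolerated on one core and does not show that this result carries over to another core, where the surroundings of the group also differ. The same change on the other core cannot be read, because compound 1 and compound 2 both give only a limit of the assay and no number: the limit of > 100000 nM in this assay, at which 2 of the 4 values shown sit.

Going by these compounds, whether an amine, a carboxylic acid or a longer chain such as ethoxy would fit at the place of the methyl in compound 3 as well as methoxy does remains open. Also open is which of the differences between the core of compound 2 and the core of compound 3 separates a limit from a number, as those cores differ in more than one place and the compounds shown do not take these differences apart.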